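The source may report more compounds than this note shows. Statements on the series, on what has been measured and on what is new or still open speak of the compounds shown alone.

Measured compounds:
compound 1, `CCCCCc1ccc(NS(=O)(=O)c2ccc(N3CCNC3=O)cc2)cc1`, gives 990 nM
compound 2, `COc1cccc(NS(=O)(=O)c2ccc(N3CCNC3=O)cc2)c1`, gives 120 nM

Both numbers come from a functional assay on HT-29 cells (Homo sapiens) for antiproliferative activity, read by sulforhodamine B assay, with a stated time of 48 h; on this read-out lower numbers stand for stronger inhibition and higher numbers for weaker inhibition. Compound 2 holds the lower of the two, and compound 1 stands higher by a gap that exceeds the scatter. Compound 1 and compound 2 differ in more than one place, so the gap is not attributed to any single change; it shows only that, within this pair, the 3-methoxyphenyl on the sulfonamide nitrogen goes with the lower number.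

Compound 3, `Cc1ccc(NS(=O)(=O)c2ccc(N3CCNC3=O)cc2)cc1`, is not yet measured. It departs from compound 2 as follows: 4-methylphenyl in place of 3-methoxyphenyl on a sulfonamide nitrogen. Going by the values given here, no measured pair isolates this change. The entering 4-methylphenyl resembles the 4-pentylphenyl of compound 1 in bearing a plain alkyl group, though a much shorter one, and compound 1 sits well above compound 2 in this assay. A step toward weaker inhibition is therefore expected, likely smaller than the gap from compound 2 to compound 1, of about a 2.5-fold higher number from compound 2 to compound 3 (0.40 log units; beyond the scatter). Compound 3 is estimated at 300 nM, expected within 100 nM to 1000 nM.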

Compound 3, half-maximal inhibitory concentration: 480 nM
Compound 3: middle estimate off by 1.6-fold (0.20 log units), on the low side, within the range that was stated.
By their numbers in this assay, from the lowest: compound 2; then compound 3; then compound 1.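

In this assay, the sulfonamide nitrogen no longer rests on a comparison of compounds differing in several places: 4-methylphenyl in place of 3-methoxyphenyl gives a 4.0-fold higher number from compound 2 to compound 3 (0.60 log units; beyond the scatter) in a single change, so the aryl group at this position alters the read-out beyond the scatter. The 4-methylphenyl also links compound 3 to the 4-pentylphenyl of compound 1, and hydrogen in place of butyl on the saturated chain carbon gives a 2.1-fold lower number from compound 1 to compound 3 (0.31 log units; beyond the scatter) as a second step beyond the scatter, so the shorter chain goes with the lower number in this one pair only. No measured property of these groups accompanies either step, and the data assign no cause to them.

As far as these compounds go, since 3-methoxyphenyl and 4-methylphenyl differ in both the group and its ring position, a 4-methoxyphenyl or a 3-methylphenyl on the sulfonamide nitrogen would be needed to separate the two, and the reading of the step stays open until then. Also open, from the compounds shown here alone, is how a 4-ethylphenyl or 4-propylphenyl would fall relative to the two alkyl compounds, and whether an amine or a carboxylic acid on the aryl ring would be tolerated at all.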